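Methoxy on the Phenyl Ring: Two Parallel Steps

The source may report more compounds than this note shows. Statements on the series, on what has been measured and on what is new or still open speak of the compounds shown alone.

Compound 1, `O[C@@H](c1ccccc1)[C@H]1CO[C@H](c2ccccc2)[C@@H](C/C=C/c2ccccc2)C1`, is the simplest member of the set and in a functional assay on HeLa cells (Homo sapiens) for cytotoxicity, read by WST assay, with a stated time of 48 h (a lower number here means a stronger inhibitor, a higher number a weaker inhibitor), compound 1 gives 6060 nM. Compound 3, `COc1ccc(/C=C/C[C@H]2C[C@@H]([C@@H](O)c3ccccc3)CO[C@@H]2c2ccccc2)cc1`, differs from it by methoxy in place of hydrogen on an aromatic carbon, and in this assay compound 3 gives 8300 nM; the step of a 1.4-fold higher number from compound 1 to compound 3 (0.14 log units; within the scatter) shows that this change barely moves the read-out in this assay. Compound 2, `COc1ccc(/C=C/C[C@H]2C[C@@H]([C@@H](O)c3ccc(OC)c(OC)c3)CO[C@@H]2c2ccccc2)cc1OC`, carries further methoxy groups on two of its aromatic rings; how its core differs from that of compound 1 is not broken down here. In this assay compound 2 gives 17000 nM, the highest number of the three measured compounds. Compound 4, `COc1ccc([C@H]2OC[C@H]([C@@H](O)c3ccc(OC)c(OC)c3)C[C@@H]2C/C=C/c2ccc(OC)c(OC)c2)cc1`, stands to compound 2 as compound 3 stands to compound 1: it differs by methoxy in place of hydrogen on an aromatic carbon, the same change at the same kind of place. Because the step of a 1.4-fold higher number from compound 1 to compound 3 (0.14 log units; within the scatter) is small, compound 4 is expected to sit close to compound 2, with an estimated step of a 1.4-fold higher number from compound 2 to compound 4 (0.15 log units; within the scatter) in this assay. Compound 4 is therefore estimated at 24000 nM, with a likely range from 10000 nM to 55000 nM.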

Compound 4, half-maximal inhibitory concentration: 46700 nM
Compound 4: middle estimate off by 1.9-fold (0.29 log units), on the low side, within the range that was stated.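

On the second core, methoxy in place of hydrogen on an aromatic carbon, read one bond further out as phenyl to 4-methoxyphenyl, gives a 2.7-fold higher number from compound 2 to compound 4 (0.44 log units; beyond the scatter) in this assay and so lies beyond the scatter, while the earlier step on the core of compound 1 lay within it. Among these compounds, this one result does not show that the change carries over to other cores with the same size, as the series offers only two such pairs and they cannot tell why the steps look different or whether the difference is real. Even so, the two steps cannot be told apart, so within these two pairs the change behaves alike on both cores: the same change on two cores in this assay, a 1.4-fold higher number (0.14 log units; within the scatter) from compound 1 to compound 3 and a 2.7-fold higher number (0.44 log units; beyond the scatter) from compound 2 to compound 4, 2.0-fold (0.30 log units) apart, within the scatter of two such steps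

The compounds shown leave open what an amine, a carboxylic acid or a fluorine atom would do at this place on the aromatic ring, para to a large group. They also leave open whether a longer chain on the oxygen, such as ethoxy, would give a step of similar size on either core.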